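This account rests on a few compounds, and the source may have more. Where it says the series, first, only, none or still open, it means among the compounds named here.

Compound 1 `COc1cc2ncnc(NCc3cccc(NC(=O)Nc4ccccc4C)c3)c2cc1OC`: > 50000 nM (a limit)
Compound 2 `COc1cc2ncnc(NCc3cccc(NC(=O)Nc4ccc(C)cc4)c3)c2cc1OC`: > 50000 nM (a limit)
Compound 3 `COc1cc2ncnc(NCc3cccc(NC(=O)Nc4ccccc4F)c3)c2cc1OC`: 24900 nM
Compound 4 `COc1cc2ncnc(NCc3cccc(NC(=O)Nc4cccc(C(F)(F)F)c4)c3)c2cc1OC`: not yet measured

Among the measured compounds shown here, in a functional assay on HepG2 cells (Homo sapiens) for antiproliferative activity, read by MTT assay (on this read-out lower numbers stand for stronger inhibition and higher numbers for weaker inhibition), compound 3 gives 24900 nM, the only true number so far. Compound 1 and compound 2 show only (the limit of > 50000 nM in this assay, at which 2 of the 3 values shown sit).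

The change to compound 4 is 3-(trifluoromethyl)phenyl in place of 2-fluorophenyl on an amide-type nitrogen.

Two measured steps alter the group at this place: an at least 2.0-fold lower number from compound 1 to compound 3 (0.30 log units; that floor lies within the scatter) and an at least 2.0-fold lower number from compound 2 to compound 3 (0.30 log units; that floor lies within the scatter). Both are floors, and neither involves trifluoromethyl. The third, a step that the two limits leave unreadable from compound 1 to compound 2, adds nothing on size.

With no direction supported, the expectation in this assay is no step beyond the scatter, and the estimate stays anchored on compound 3 at 24900 nM. The expected change is a 1.1-fold higher number from compound 3 to compound 4 (0.05 log units; within the scatter). The estimated value for compound 4 is 28000 nM, with an expected range of 10000 nM to 70000 nM.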

Compound 4, half-maximal inhibitory concentration: 34200 nM
Estimate against measurement, compound 4: 1.2-fold (0.09 log units) below, within the range that was stated.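

On the amide-type nitrogen, 3-(trifluoromethyl)phenyl gives a second true number in this assay and the step of a 1.4-fold higher number from compound 3 to compound 4 (0.14 log units; within the scatter) leaves it level with 2-fluorophenyl. Against the two methylphenyl compounds only floors can be read, with an at least 1.4-fold lower number from compound 2 to compound 4 (0.16 log units; that floor lies within the scatter) and an at least 1.4-fold lower number from compound 1 to compound 4 (0.16 log units; that floor lies within the scatter) as all that these pairs give. Compound 1 and compound 2 remain limits and not numbers: the limit of > 50000 nM in this assay, at which 2 of the 4 values shown sit.

As far as these compounds go, whether any group at this place brings the number well beyond the scatter from those of compound 3 and compound 4 stays open. Candidates would be a phenyl carrying a carboxylic acid or an amine, or a longer chain.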